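Benzylidene variation in the bis-cinnamoyl series

The compounds below may be only part of what the source reports. "The series", "measured", "known", "first", "only" and "open" are said of these compounds alone.

compound 1 `COc1ccc(OC)c(/C=C/C(=O)/C=C(O)/C=C/c2cc(OC)ccc2OC)c1` gives 5560 nM
compound 2 `COc1ccc(C=C(C(=O)/C=C/c2cccc(OC)c2OC)C(=O)/C=C/c2cccc(OC)c2OC)cc1OC` gives 200 nM
compound 3 `COc1cccc(/C=C/C(=O)C(=Cc2cc(OC)c(OC)c(OC)c2)C(=O)/C=C/c2cccc(OC)c2OC)c1OC` gives 220 nM

In a functional assay on HepG2 cells (Homo sapiens) for antiproliferative activity, read by sulforhodamine B assay, with a stated time of 48 h (a higher number here means a weaker inhibitor, a lower number a stronger inhibitor), compound 3 sits level with compound 2, and compound 1 carries a clearly higher number than either. Compound 4 `COc1cccc(C=C(C(=O)/C=C/c2cccc(OC)c2OC)C(=O)/C=C/c2cccc(OC)c2OC)c1OC` follows from compound 3 by the change 2,3-dimethoxyphenyl in place of 3,4,5-trimethoxyphenyl on a double-bonded chain carbon bound to a double-bonded chain carbon. Within the data shown here, the one measured step that bears on this, a 1.1-fold higher number from compound 2 to compound 3 (0.04 log units; within the scatter) (methoxy in place of hydrogen on an aromatic carbon), stayed within the scatter. Among the measured compounds shown here, no measured step shows this exact exchange, so the read-across is loose. No step beyond the scatter is therefore expected in this assay and no firm direction. The estimated step is a 1.1-fold higher number from compound 3 to compound 4 (0.06 log units; within the scatter) in size. For compound 4 the expected value is 250 nM (estimated range 100 nM to 650 nM).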

Compound 4, half-maximal inhibitory concentration: 230 nM
Beside the measured number, compound 4's estimate is 1.1-fold (0.04 log units) above it, and the stated range covers the measured number.
By their numbers in this assay, from the lowest: compounds 2, 3 and 4 (each within the scatter of the next); then compound 1.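

At the double-bonded chain carbon bound to a double-bonded chain carbon, 2,3-dimethoxyphenyl replacing 3,4,5-trimethoxyphenyl gives a 1.0-fold higher number from compound 3 to compound 4 (0.02 log units; within the scatter) in this assay and replacing 3,4-dimethoxyphenyl gives a 1.2-fold higher number from compound 2 to compound 4 (0.06 log units; within the scatter) at the same place. Both steps lie within the scatter, so compound 2, compound 3 and compound 4 read level across these three methoxy patterns. No available evidence accounts for this.

Open, going by these compounds, is whether an amine or a carboxylic acid on this phenyl group, in place of methoxy, would shift the number in this assay beyond the scatter.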